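Amino in Place of Ethoxy on a Triazene Ester

The source may hold more compounds than are shown below. What is called first, only, known or untested is meant among the compounds shown, and "the series" means these compounds.

Measured so far:
compound 1, `CN(/N=N/c1ccc(C(N)=O)cc1)c1cccs1`, 2.9
compound 2, `CCOC(=O)c1ccc(/N=N/N(C)CC)cc1`, 3.01

Both numbers come from a functional assay on L1210 cells (Mus musculus) for antiproliferative activity; a higher number here means a more potent compound, by a factor of ten per unit of this negative logarithm, a lower number a less potent compound. Going by the values given here, compound 1 with 2.9 and compound 2 with 3.01 cannot be told apart on these numbers, since the gap between them falls within the usual scatter of repeated measurements; compound 2 therefore stands level with the only other compound measured. Compound 3, `CCN(C)/N=N/c1ccc(C(N)=O)cc1`, is not yet measured. It differs from compound 2 in one place: amino in place of ethoxy on a carbonyl carbon. Among the compounds with values here, no step between measured compounds shows what this change does on its own, and nothing else here bears on it. The expected step from compound 2 to compound 3 in this assay is a number 0.01 log units lower from compound 2 to compound 3 (within the scatter), which is none beyond the scatter. Compound 3 is therefore estimated at 3, with a range from 2.5 to 3.5.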

Compound 3, logarithm of the reciprocal of the active concentration, log(1/C): 3.66
The estimate for compound 3 lay 0.66 log units below the measured number, outside the stated range (above it).
By their numbers in this assay, from the lowest: compounds 1 and 2 (each within the scatter of the next); then compound 3.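

In this assay, the carbonyl carbon bound to an aromatic carbon proves to be a place where one small change can move the number beyond the scatter: going from ethoxycarbonyl to carbamoyl, with amino in place of ethoxy, gives a number 0.65 log units higher from compound 2 to compound 3 (beyond the scatter), a modest step. With the carbamoyl group kept, the amine nitrogen also matters, since ethyl in place of thiophen-2-yl gives a number 0.76 log units higher from compound 1 to compound 3 (beyond the scatter), which leaves compound 3 clearly ahead of the other two. Nothing available here explains why either change acts as it does.

From the compounds shown here alone, it remains open whether a methylamino group or a hydroxyl on the same carbonyl carbon, the latter giving a carboxylic acid, would keep this gain. Going by these compounds, it is also open whether amino in place of ethoxy does the same when thiophen-2-yl sits on the amine nitrogen.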